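Methyl for methoxy on the ketone aryl of compound 2

The source may hold more compounds than are shown below. What is called first, only, known or untested is meant among the compounds shown, and "the series" means these compounds.

Measured so far:
compound 1, `COC(=O)c1c(Nc2ccccc2)sc(C(=O)c2ccc(C)cc2)c1C`, 10.3%
compound 2, `COc1ccc(C(=O)c2sc(Nc3ccccc3)c(C(=O)O)c2C)cc1`, 61.2%

In a functional assay, with a stated time of 150 min, tested at 35 ug/mL (a higher number here means a stronger effect of the compound at the concentration tested, a lower number a weaker effect), compound 2 stands highest of the two, and the gap to compound 1 lies beyond the scatter. Compound 3, `Cc1ccc(C(=O)c2sc(Nc3ccccc3)c(C(=O)O)c2C)cc1`, is not yet measured. It differs from compound 2 in one place: methyl in place of methoxy on an aromatic carbon. Among the compounds with values here, no step of this exact kind has been measured here, so its size is unknown. Compound 1, which shows the same methyl, sits far lower, but it differs in more than one place. Compound 3 is expected to lose some activity, a step of a number 19.2 percentage points lower from compound 2 to compound 3 (beyond the scatter), with wide uncertainty. Compound 3 is therefore estimated at 42%, between 12% and 66%.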

Compound 3, a percentage reported as activity, at one concentration (the size of the read-out at that concentration, not a potency): 5.55%
Beside the measured number, compound 3's estimate is 36.5 percentage points above it, and the stated range ends above it.
By their numbers in this assay, from the lowest: compounds 3 and 1 (each within the scatter of the next); then compound 2.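

In this assay, going from 4-methoxyphenyl to 4-methylphenyl gives a number 55.7 percentage points lower from compound 2 to compound 3 (beyond the scatter), so activity at this position depends strongly on which of these two groups is present. Turning the methyl ester into the free carboxylic acid while keeping 4-methylphenyl gives a number 4.8 percentage points lower from compound 1 to compound 3 (within the scatter), so with this aryl group the two compounds cannot be told apart. Nothing given here explains the large step.

The compounds shown leave open whether a hydroxyl or an ethoxy group at this position would match methoxy. They also leave open how the methyl ester behaves alongside 4-methoxyphenyl.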